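This account rests on a few compounds, and the source may have more. Where it says the series, first, only, none or still open, it means among the compounds named here.

For the measured compounds named here, compound 3 `CC(C)C[N+]1(C)CCc2c(sc(NC(=O)Nc3ccc(Cl)cc3)c2C(N)=O)C1` gives 380 nM in a functional assay (strain AB) with Danio rerio as the target, read by microscopy, with a stated time of 1 h (on this read-out lower numbers stand for an effect already at smaller amounts and higher numbers for an effect only at larger amounts of compound), and stands highest of the three numbers so far; compound 1 `CC(C)(C)C[N+]1(C)CCc2c(sc(NC(=O)Nc3ccc(Cl)cc3)c2C(N)=O)C1` gives 290 nM, which lies within the scatter of compound 3, and compound 2 `CC(C)(C)OC(=O)CCCC[N+]1(C)CCc2c(sc(NC(=O)Nc3ccc(Cl)cc3)c2C(N)=O)C1` gives 140 nM. Compound 4 `C[N+]1(CC2CC2)CCc2c(sc(NC(=O)Nc3ccc(Cl)cc3)c2C(N)=O)C1` differs from compound 3 by cyclopropyl in place of isopropyl on a saturated chain carbon bound to an amine nitrogen in a ring. Going by the values given here, no measured pair exchanges an open branch for a ring at this place. The nearest steps are a 1.3-fold higher number from compound 1 to compound 3 (0.12 log units; within the scatter) and a 2.1-fold lower number from compound 1 to compound 2 (0.32 log units; beyond the scatter): trimming the branch moved the number little, while a longer chain lowered it modestly. A change of similar size to the group in compound 3 is therefore expected to shift this assay by no more than the scatter, a 1.2-fold lower number from compound 3 to compound 4 (0.07 log units; within the scatter). Compound 4 is expected to give 320 nM, between 150 nM and 700 nM.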

Compound 4, half-maximal effective concentration: 360 nM
The estimate for compound 4 lay 1.1-fold (0.05 log units) below the measured number, and the stated range covers the measured number.
By their numbers in this assay, from the lowest: compound 2; then compounds 1, 4 and 3 (each within the scatter of the next).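

In this assay, a ring can take the place of an open branch here without a reading change: cyclopropyl for isopropyl stays within the scatter (a 1.1-fold lower number from compound 3 to compound 4 (0.02 log units; within the scatter)), as does cyclopropyl for tert-butyl (a 1.2-fold higher number from compound 1 to compound 4 (0.09 log units; within the scatter)). Only 3-(tert-butoxycarbonyl)propyl stands apart from cyclopropyl (a 2.6-fold higher number from compound 2 to compound 4 (0.41 log units; beyond the scatter)), so compounds 1, 3 and 4 form one group at this place. Nothing measured explains this result.

Still open, on these data alone, is whether the lower number of compound 2 goes with its longer chain or its ester, and how an amine or a carboxylic acid at this place would read.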